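This account rests on a few compounds, and the source may have more. Where it says the series, first, only, none or still open, it means among the compounds named here.

In an ADME assay on Vero 76 cells (Chlorocebus sabaeus) for cytotoxicity, read by microscopy (on this read-out higher numbers stand for lower toxicity in this test and lower numbers for higher toxicity in this test), compound 1 `OC[C@@]12C[C@@H]1[C@@H](n1cnc3c(NCc4ccccc4)nc(Cl)nc31)[C@H](O)[C@@H]2O` gives > 100000 nM, which is a limit of the assay and not a number. Within the data shown here, compound 2 `OC[C@@]12C[C@@H]1[C@@H](n1cnc3c(NC(C4CCC4)C4CCC4)nc(Cl)nc31)[C@H](O)[C@@H]2O` gives 50000 nM, the only actual number so far. Compound 3 `CC(C)(C)[C@H](Nc1nc(Cl)nc2c1ncn2[C@H]1[C@H](O)[C@H](O)[C@]2(CO)C[C@H]12)C1CC1` differs from compound 2 as follows: 1-cyclopropyl-2,2-dimethylpropyl in place of dicyclobutylmethyl on a nitrogen on an aromatic ring. Among the measured compounds shown here, the one measured step at this nitrogen, an at least 2.0-fold lower number from compound 1 to compound 2 (0.30 log units; that floor lies within the scatter), is a floor set by that limit and offers only weak guidance. No step beyond the scatter is therefore expected in this assay, and no direction is favoured. The estimated step is a 1.2-fold higher number from compound 2 to compound 3 (0.08 log units; within the scatter). The expected value for compound 3 is 60000 nM, with an estimated range of 25000 nM to 100000 nM.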

Compound 3, half-maximal cytotoxic concentration: > 100000 nM
Compound 3: only a limit was reported; the forecaster's own chance of this, stated with the estimate: 30%; middle value at least 1.6-fold (0.22 log units) from the limit.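

In this assay, compound 3, with 1-cyclopropyl-2,2-dimethylpropyl on this nitrogen, is reported only as a limit, as compound 1 with benzyl is, so dicyclobutylmethyl in compound 2 alone carries an actual number. The change reads as an at least 2.0-fold higher number from compound 2 to compound 3 (0.30 log units; that floor lies within the scatter), while the step between compound 1 and compound 3 cannot be read. Most readings at this nitrogen give no size: the limit of > 100000 nM in this assay, at which 2 of the 3 values shown sit.

On these data alone, how a carboxylic acid or a longer chain of carbon on this nitrogen would read in this assay remains open.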